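Removing the Bromo Substituent from Compound 3

The source may hold more compounds than are shown below. What is called first, only, known or untested is meant among the compounds shown, and "the series" means these compounds.

Measured so far:
- compound 1, `O=C(Nc1cc(C(F)(F)F)cc(C(F)(F)F)c1)c1cc(Cl)c(-c2ccccc2)cc1O`: 560 nM
- compound 2, `O=C(Nc1cc(C(F)(F)F)cc(C(F)(F)F)c1)c1ccc(Cl)cc1O`: 850 nM
- compound 3, `O=C(Nc1cc(C(F)(F)F)cc(C(F)(F)F)c1)c1cc(Br)c(-c2ccccc2)cc1O`: 840 nM

All three compounds were tested in a functional assay on NALM-6 cells (Homo sapiens) for cytotoxicity, read by luminescence and CellTiter-Glo, with a stated time of 3 days; on this read-out lower numbers stand for stronger inhibition and higher numbers for weaker inhibition. Compound 3 gives 840 nM and stands second highest of the three numbers. Its nearest neighbour is compound 2 at 850 nM, and the two values are within the scatter of each other. Compound 1, with 560 nM, is the furthest away, yet the step of a 1.5-fold higher number from compound 1 to compound 3 (0.18 log units; within the scatter) is also within the scatter, so the three compounds are not separated by the measurements at hand.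

Compound 4, `O=C(Nc1cc(C(F)(F)F)cc(C(F)(F)F)c1)c1ccc(-c2ccccc2)cc1O`, has not yet been measured. It differs from compound 3 in one place: hydrogen in place of bromo on an aromatic carbon. For the measured compounds named here, the only measured step that touches this site, a 1.5-fold higher number from compound 1 to compound 3 (0.18 log units; within the scatter), exchanged one halogen for another and moved the number only a little. Going by the values given here, no measured pair shows the halogen being removed altogether, and compound 2 differs from compound 4 in more than one place, so it gives no direct guidance. Compound 4 is therefore expected to land near compound 3, with a step of a 1.2-fold higher number from compound 3 to compound 4 (0.08 log units; within the scatter) that is not expected to exceed the scatter. The estimate for compound 4 is 1000 nM, within a range from 400 nM to 2500 nM.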

Compound 4, half-maximal inhibitory concentration: 1580 nM
Compound 4: middle estimate off by 1.6-fold (0.20 log units), on the low side; the measured number falls inside the stated range.
By their numbers in this assay, from the lowest: compounds 1, 3, 2 and 4 (each within the scatter of the next, the first and the last beyond it).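

In this assay, compound 4 gives the first view of the aromatic carbon ortho to a phenyl group and para to a hydroxy group with no halogen on it, and the two halogens do not read the same against hydrogen there: hydrogen in place of chloro gives a 2.8-fold higher number from compound 1 to compound 4 (0.45 log units; beyond the scatter), a modest step, while hydrogen in place of bromo gives a 1.9-fold higher number from compound 3 to compound 4 (0.27 log units; within the scatter), so compound 3 goes against any general claim that losing a halogen here costs activity. The other new pair gives a 1.9-fold higher number from compound 2 to compound 4 (0.27 log units; within the scatter) and does not separate those two compounds. Nothing at hand explains why the chloro pair alone goes beyond the scatter.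

The compounds shown leave open how this carbon would respond to a fluoro, methyl, methoxy or amine group, since only chloro, bromo and hydrogen appear there. They also leave open whether the small gap seen with chloro would hold up in a larger set carrying the phenyl group.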